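Moving the ring nitrogen of a pyridinyl on a piperazine

The compounds below may be only part of what the source reports. "The series", "measured", "known", "first", "only" and "open" are said of these compounds alone.

Within the data shown here, compound 2 `Nc1scc(CN2CCN(c3cccnc3)CC2)c1C(=O)c1ccc(Cl)cc1` is the stronger-reading of the two compounds so far in a functional assay on CHO cells with adenosine receptor A1 (Homo sapiens) as the target, read by cAMP accumulation and immunoassay, with a stated time of 6 min, tested at 1 uM (on this read-out higher numbers stand for a weaker effect at the one concentration tested and lower numbers for a stronger effect), where compound 2 gives -2.7%. Among the measured compounds shown here, the only other measured compound, compound 1 `Nc1scc(CN2CCN(c3ccc(F)cc3Cl)CC2)c1C(=O)c1ccc(Cl)cc1`, gives -39% in this assay, and the single measured step, a number 36.3 percentage points higher from compound 1 to compound 2 (beyond the scatter), is large and lies beyond the scatter. Compound 3 `Nc1scc(CN2CCN(c3ccncc3)CC2)c1C(=O)c1ccc(Cl)cc1` differs from compound 2 by pyridin-4-yl in place of pyridin-3-yl on an amine nitrogen in a ring, the change sitting on an amine nitrogen in a ring of a six-membered non-aromatic ring with two nitrogens. For the measured compounds named here, no measured step touches this kind of change: the one step known swaps a chloro-fluoro-phenyl for a pyridinyl, not one pyridinyl for another. With nothing to anchor a direction, compound 3 is expected to stay near compound 2, with a step of a number 2.3 percentage points lower from compound 2 to compound 3 (within the scatter), and its expected value in this assay is -5%, estimated to lie between -35% and 15%.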

Compound 3, a percentage reported as activity, at one concentration (the size of the read-out at that concentration, not a potency): -8.3%
Compound 3: the middle estimate sits 3.3 percentage points above what was measured, and the stated range covers the measured number.
By their numbers in this assay, from the lowest: compound 1; then compounds 3 and 2 (each within the scatter of the next).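

In this assay, pyridin-4-yl in place of pyridin-3-yl gives a number 5.6 percentage points lower from compound 2 to compound 3 (within the scatter) and so does not separate the two groups at this position. Replacing 2-chloro-4-fluorophenyl with this second pyridinyl gives a number 30.7 percentage points higher from compound 1 to compound 3 (beyond the scatter) and shows that the large step is not confined to pyridin-3-yl, since both pyridinyl compounds read apart from compound 1. No evidence is available to explain why these numbers fall as they do.

As far as these compounds go, it remains open whether pyridin-2-yl or an unsubstituted phenyl on the same amine nitrogen would read with the two pyridinyl compounds or with compound 1. From the compounds shown here alone, it is also open whether an amine or a carboxylic acid on the pyridinyl ring would move the read-out beyond the scatter.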